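Swapping Methoxy for Hydrogen on Compound 2

The compounds below may be only part of what the source reports. "The series", "measured", "known", "first", "only" and "open" are said of these compounds alone.

In a functional assay on EA.hy 926 cells (Homo sapiens) for cytotoxicity, read by MTT assay, with stated times of 24 h and 12 h (on this read-out lower numbers stand for an effect already at smaller amounts and higher numbers for an effect only at larger amounts of compound), compound 1 (`Cc1nc(C)c(C(=O)Oc2ccc(/C=C/C(=O)O)cc2)nc1C`) gives 38000 nM and compound 2 (`CCOC(=O)/C=C/c1ccc(OC(=O)c2nc(C)c(C)nc2C)c(OC)c1`) gives 38600 nM as its value, so compound 2 stands level with compound 1 within the usual scatter of repeated measurements. Compound 3 (`CCOC(=O)/C=C/c1ccc(OC(=O)c2nc(C)c(C)nc2C)cc1`) carries hydrogen in place of methoxy on an aromatic carbon. For the measured compounds named here, no measured pair yet shows what a single change does here, so the expectation is cautious: no shift beyond the scatter in this assay for this change. The expected step is a 1.1-fold lower number from compound 2 to compound 3 (0.04 log units; within the scatter) and would stay within that scatter. For compound 3 the estimated value is 35000 nM with an expected range from 15000 nM to 80000 nM around it.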

Compound 3, half-maximal effective concentration: 34900 nM
For compound 3 the middle estimate is 1.0-fold (0.00 log units) above the measured one; the range from low to high includes it.
By their numbers in this assay, from the lowest: compounds 3, 1 and 2 (each within the scatter of the next).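

In this assay, for the compounds shown here, the step for hydrogen in place of methoxy on an aromatic carbon is a 1.1-fold lower number from compound 2 to compound 3 (0.04 log units; within the scatter) and gives the first single-place reading at this position, with no shift beyond the scatter. Ethyl in place of hydrogen on an oxygen next to a carbonyl group likewise gives a 1.1-fold lower number from compound 1 to compound 3 (0.04 log units; within the scatter) and so also stays within the scatter. No supporting data offer a reason for either result. On these data alone, it remains open whether an amine on that aromatic carbon, or a longer chain in place of the ethyl, would shift the number beyond the scatter.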